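The source may hold more compounds than are shown below. What is called first, only, known or untested is meant among the compounds shown, and "the series" means these compounds.

Of the compounds shown here, three that share one core have been tested in an ADME assay on Vero cells (Chlorocebus sabaeus) for cytotoxicity, read by resazurin assay, with a stated time of 72 h; a higher number here means a weaker inhibitor, a lower number a stronger inhibitor. Compound 1 `O=C(CCN1CCN(c2ccc(Cl)cc2)CC1)c1ccc(F)c(F)c1` gives 86200 nM in this assay. Compound 2 `O=C(CCN1CCN(c2ccc([N+](=O)[O-])cc2)CC1)c1ccc(F)c(F)c1` differs from compound 1 by nitro in place of chloro on an aromatic carbon; in this assay compound 2 gives 122000 nM, so the step of a 1.4-fold higher number from compound 1 to compound 2 (0.15 log units; within the scatter). Compound 3 `O=C(CCN1CCN(c2ccc(Cl)cc2)CC1)c1ccc(F)c(Cl)c1` differs from compound 1 by chloro in place of fluoro on an aromatic carbon; in this assay compound 3 gives 114000 nM, and the step of a 1.3-fold higher number from compound 1 to compound 3 (0.12 log units; within the scatter). The three numbers therefore sit close together, and none of them stands apart from the others.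

Compound 4 `O=C(CCN1CCN(c2ccc([N+](=O)[O-])cc2)CC1)c1ccc(F)c(Cl)c1` has not yet been measured. It relates to compound 3 as compound 2 relates to compound 1: the difference is nitro in place of chloro on an aromatic carbon, and the description of the place where it occurs matches the earlier one word for word, so this is the same change, only made on the core of compound 3 instead of the core of compound 1. Because that change earlier gave a 1.4-fold higher number from compound 1 to compound 2 (0.15 log units; within the scatter), the expected step is a 1.3-fold higher number from compound 3 to compound 4 (0.12 log units; within the scatter), a small shift that should stay inside the usual spread of repeated measurements. Compound 4 is thus estimated to give about 150000 nM in this assay, most likely falling between 80000 nM and 280000 nM.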

Compound 4, half-maximal inhibitory concentration: 116000 nM
Compound 4: the middle estimate sits 1.3-fold (0.11 log units) above what was measured; the measured number falls inside the stated range.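

Nitro in place of chloro, carried over to the core of compound 3, gives a 1.0-fold higher number from compound 3 to compound 4 (0.01 log units; within the scatter) in this assay, and this step agrees with the one seen on the core of compound 1: the same change on two cores in this assay, a 1.4-fold higher number (0.15 log units; within the scatter) from compound 1 to compound 2 and a 1.0-fold higher number (0.01 log units; within the scatter) from compound 3 to compound 4, 1.4-fold (0.14 log units) apart, within the scatter of two such steps. Chloro in place of fluoro, carried over to the core of compound 2, gives a 1.1-fold lower number from compound 2 to compound 4 (0.02 log units; within the scatter), and this step also agrees with its earlier counterpart: the same change on two cores in this assay, a 1.3-fold higher number (0.12 log units; within the scatter) from compound 1 to compound 3 and a 1.1-fold lower number (0.02 log units; within the scatter) from compound 2 to compound 4, 1.4-fold (0.14 log units) apart, within the scatter of two such steps. Among the compounds shown here, on these four compounds, then, each change stays within the scatter on both cores, which shows that neither change leaves a readable mark, but it does not show that a real, sizeable step would carry from one core to another, as no such step appears here to be tested.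

As far as these compounds go, it remains open whether any change at these places can move the number in this assay beyond the scatter at all. An amine or a carboxylic acid on the same aromatic carbon, or a longer chain in the shared core, could answer that question and give a step large enough for a real test of carrying a change between cores.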